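This account rests on a few compounds, and the source may have more. Where it says the series, first, only, none or still open, it means among the compounds named here.

Measured in a functional assay on SW-620 cells (Homo sapiens) for cytotoxicity, read by sulforhodamine B assay, with a stated time of 48 h; a higher number here means a weaker inhibitor, a lower number a stronger inhibitor:
compound 1 `C[C@H]1CC[C@@H]2[C@@H](OC(=O)[C@]23CC(c2ccc(O)cc2)=NO3)[C@]2(C)C(=O)C=C[C@@]12O`: 89000 nM
compound 2 `C[C@H]1CC[C@@H]2[C@@H](OC(=O)[C@]23CC(c2ccccc2[N+](=O)[O-])=NO3)[C@]2(C)C(=O)C=C[C@@]12O`: 40000 nM
compound 3 `C[C@H]1CC[C@@H]2[C@@H](OC(=O)[C@]23CC(c2ccccc2Cl)=NO3)[C@]2(C)C(=O)C=C[C@@]12O`: 9000 nM

Compound 1 has the highest number of the three, and both steps away from it lie beyond the scatter. Compound 4 `Cc1ccccc1C1=NO[C@]2(C1)C(=O)O[C@@H]1[C@H]2CC[C@H](C)[C@]2(O)C=CC(=O)[C@@]12C` differs from it by 2-methylphenyl in place of 4-hydroxyphenyl on a carbon with a double bond to nitrogen, with 2-methylphenyl in place of 4-hydroxyphenyl on a carbon with a double bond to nitrogen. Two measured steps replace the same 4-hydroxyphenyl: a 2.2-fold lower number from compound 1 to compound 2 (0.35 log units; beyond the scatter) and a 9.9-fold lower number from compound 1 to compound 3 (1.00 log units; beyond the scatter). The entering group clearly matters, as a 4.4-fold lower number from compound 2 to compound 3 (0.65 log units; beyond the scatter) shows. Among the measured compounds shown here, no 2-methylphenyl compound has been measured, so a lower number of intermediate size is expected in this assay. The estimated step is a 5.6-fold lower number from compound 1 to compound 4 (0.75 log units; beyond the scatter). The estimate for compound 4 is 16000 nM, with an expected range of 5000 nM to 45000 nM.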

Compound 4, half-maximal inhibitory concentration: 5000 nM
Estimate against measurement, compound 4: 3.2-fold (0.51 log units) above; low and high end bracket the measured number.
By their numbers in this assay, from the lowest: compounds 4 and 3 (each within the scatter of the next); then compound 2; then compound 1.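

In this assay, among the compounds shown here, 2-methylphenyl gives the largest step at this position so far (an 18-fold lower number from compound 1 to compound 4 (1.25 log units; beyond the scatter)). Methyl and chloro on the aromatic carbon cannot be separated (a 1.8-fold lower number from compound 3 to compound 4 (0.26 log units; within the scatter)), while methyl in place of nitro does separate (an 8.0-fold lower number from compound 2 to compound 4 (0.90 log units; beyond the scatter)), so among these three groups only nitro stands apart. No evidence on the cause of these differences is available.

Open, as far as these compounds go, is whether a longer chain such as ethyl, or an amine or a carboxylic acid, in place of the methyl of 2-methylphenyl would hold this level.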